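Carbamate Replaces Urea on the Piperidine Nitrogen of Compound 3

The source may report more compounds than this note shows. Statements on the series, on what has been measured and on what is new or still open speak of the compounds shown alone.

Three compounds share one core and differ only in the group on the ring amine nitrogen. Compound 1 `CC(=O)N1CCC(CN(C2Cc3cc(C#N)ccc3N(Cc3cncn3C)C2)S(=O)(=O)c2ccccn2)CC1` gives 0.5 10^-6 cm/s in an ADME assay on Caco-2 cells (Homo sapiens) for permeability, in the apical to basolateral direction; on this read-out lower numbers stand for lower permeability and higher numbers for higher permeability. Compound 2 `CCS(=O)(=O)N1CCC(CN(C2Cc3cc(C#N)ccc3N(Cc3cncn3C)C2)S(=O)(=O)c2ccccn2)CC1` gives 0.1 10^-6 cm/s, and compound 3 `CC(C)NC(=O)N1CCC(CN(C2Cc3cc(C#N)ccc3N(Cc3cncn3C)C2)S(=O)(=O)c2ccccn2)CC1` gives 0.6 10^-6 cm/s. Compound 3 holds the highest of the three numbers, yet its gap to compound 1 is within the scatter, so the two cannot be ordered; only compound 2 stands apart, with a 6.0-fold higher number from compound 2 to compound 3 (0.78 log units; beyond the scatter) and a 5.0-fold lower number from compound 1 to compound 2 (0.70 log units; beyond the scatter).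

Compound 4 `Cn1cncc1CN1CC(N(CC2CCN(C(=O)OCc3ccccc3)CC2)S(=O)(=O)c2ccccn2)Cc2cc(C#N)ccc21` has not been measured. It differs from compound 3 by benzyloxy in place of isopropylamino on a carbonyl carbon. For the measured compounds named here, the one measured step at this same carbonyl carbon, a 1.2-fold higher number from compound 1 to compound 3 (0.08 log units; within the scatter), was within the scatter, which suggests that changes here have so far moved the number little. Going by the values given here, the larger steps came from exchanging the whole group on the ring nitrogen, and no measured pair covers a benzyloxy group, so the data leave the direction open. Compound 4 is therefore expected to land close to compound 3, with a 1.7-fold higher number from compound 3 to compound 4 (0.22 log units; within the scatter) as a small rise that may not exceed the scatter. The value of compound 4 in this assay is estimated at 1 10^-6 cm/s, within a range from 0.3 10^-6 cm/s to 3 10^-6 cm/s.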

Compound 4, apparent permeability: 1 10^-6 cm/s
Compound 4: middle estimate and measured number agree at the digits printed; the range from low to high includes it.
By their numbers in this assay, from the lowest: compound 2; then compounds 1, 3 and 4 (each within the scatter of the next).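

In this assay, for the compounds shown here, the carbonyl carbon on the ring nitrogen accepts a much larger change than the earlier compounds had tested: isopropylamino, with its hydrogen-bond donor, gives way to benzyloxy, with its six-membered aromatic ring and no donor, and the result is a 1.7-fold higher number from compound 3 to compound 4 (0.22 log units; within the scatter). The comparison with the smallest group at this carbon, methyl, gives a 2.0-fold higher number from compound 1 to compound 4 (0.30 log units; within the scatter), so compounds 1, 3 and 4 cannot be ordered, even though the group on the carbonyl carbon ranges from methyl to benzyloxy. Going by these compounds alone, compound 2 remains the only compound apart from the others, and the new comparison gives a 10-fold higher number from compound 2 to compound 4 (1.00 log units; beyond the scatter), which extends the separation between the ethylsulfonyl group and the three carbonyl-linked groups to a third compound.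

The data shown offer no measurement that accounts for any of these steps. They also leave open how a carbonyl carbon bearing a simple amine such as dimethylamino, a longer chain such as phenethyloxy, or a benzyloxy ring carrying a carboxylic acid would compare with compounds 1, 3 and 4.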